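This account rests on a few compounds, and the source may have more. Where it says the series, first, only, none or still open, it means among the compounds named here.

Compound 3 `Cc1ccc2c(NCc3ccc(NC(=O)C4CCN(Cc5ccc(F)cc5Cl)CC4)cc3)nc(N(C)C)nc2c1` is examined in a functional assay on SV5A8 cells (Homo sapiens) for cytotoxicity (on this read-out higher numbers stand for weaker inhibition and lower numbers for stronger inhibition), and on that read-out compound 3 gives only a limit, > 5910 nM. The two compounds that share its core stand no differently. Compound 1 `COc1ccc(CN2CCC(C(=O)Nc3ccc(CNc4nc(N(C)C)nc5cc(C)ccc45)cc3)CC2)cc1` in this assay likewise gives only a limit, > 6180 nM. Compound 2 `Cc1ccc2c(NCc3ccc(NC(=O)C4CCN(Cc5ccccc5F)CC4)cc3)nc(N(C)C)nc2c1` in this assay again gives only a limit, > 6670 nM. With every value sitting at a limit, as the limit of > 5910 nM in this assay, at which 1 of the 3 values shown sits, the limit of > 6180 nM in this assay, at which 1 of the 3 values shown sits, and the limit of > 6670 nM in this assay, at which 1 of the 3 values shown sits, show, none of the steps between them can be read: a step that the two limits leave unreadable from compound 1 to compound 2, a step that the two limits leave unreadable from compound 1 to compound 3 and a step that the two limits leave unreadable from compound 2 to compound 3 all remain of unknown size. Compound 4 `Cc1ccc2c(NCc3ccc(NC(=O)C4CCN(Cc5ccco5)CC4)cc3)nc(N(C)C)nc2c1` differs from compound 3 by furan-2-yl in place of 2-chloro-4-fluorophenyl on a saturated chain carbon bound to an amine nitrogen in a ring. Each of the measured steps alters the same place, a saturated chain carbon bound to an amine nitrogen in a ring, yet none of them yields a readable change, so the measured steps offer no direction and no size for this assay. In this assay compound 4 is therefore expected to behave like its three relatives, with the step from compound 3 to compound 4 estimated as a step that the limit leaves unreadable from compound 3 to compound 4 and most likely unreadable. Compound 4 is estimated at 6500 nM, within a range from 2500 nM to 20000 nM, most probably reported again as a limit.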

Compound 4, half-maximal inhibitory concentration: > 20000 nM
Compound 4: a limit, no number; the forecaster's own chance of this, stated with the estimate: 80%; at least 3.0-fold (0.48 log units) between middle value and limit.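

In this assay compound 4 gives only a limit, > 20000 nM. Among the compounds shown here, compound 1, compound 2 and compound 3 also stand only at limits, and no step from any of them to compound 4 can be read. The compounds shown leave open what size any change on the saturated chain carbon bound to an amine nitrogen in a ring has in this assay.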